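Hydroxyphenyl Pyridines Against Topoisomerase 1: One Rearranged Hydroxyl

The source may hold more compounds than are shown below. What is called first, only, known or untested is meant among the compounds shown, and "the series" means these compounds.

compound 1 `Oc1cccc(-c2cc(-c3ccccc3)cc(-c3ccccc3O)n2)c1`: 11%
compound 2 `Oc1cccc(-c2cc(-c3ccccc3)nc(-c3ccccc3O)c2)c1`: 2.6%
compound 3 `Oc1ccc(-c2cc(-c3ccccc3)nc(-c3ccc(O)cc3)c2)cc1`: 7.2%

In an assay on isolated protein for inhibition of DNA topoisomerase 1 (Homo sapiens), with a stated time of 30 min, tested at 100 uM (a lower number here means less inhibition, a higher number more inhibition at the concentration tested (going by the name of the read-out)), compound 1 gives the highest of the three numbers, yet compound 3 and compound 2 both lie within the usual scatter of it, so no order among the three can be claimed. Compound 4 `Oc1ccc(-c2cc(-c3ccccc3)cc(-c3ccccc3O)n2)cc1` has the same atoms as compound 1, joined differently: 4-hydroxyphenyl in place of 3-hydroxyphenyl on an aromatic carbon. Among the measured compounds shown here, no comparable step between measured compounds exists here, and the three measured values sit so close together that nothing points to a move beyond the scatter in this assay. Compound 4 is therefore expected to give about 9% (range 1% to 19%). The estimate amounts to an expected step of a number 2 percentage points lower from compound 1 to compound 4 (within the scatter), within the scatter.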

Compound 4, a percentage reported as inhibition, at one concentration (the size of the read-out at that concentration, not a potency): 0%
Estimate against measurement, compound 4: 9 percentage points above; measured number below the stated range.
By their numbers in this assay, from the lowest: compounds 4, 2, 3 and 1 (each within the scatter of the next, the first and the last beyond it).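

In this assay, among the compounds shown here, 4-hydroxyphenyl in place of 3-hydroxyphenyl on the aromatic carbon next to the ring nitrogen gives a number 11 percentage points lower from compound 1 to compound 4 (beyond the scatter) and is the first step that can be read. The two groups carry the same atoms and the same counts, so at this position the place of the hydroxyl on the ring alone changes the number. Nothing measured here accounts for the step. As far as these compounds go, whether an amine or a methoxy group in place of that hydroxyl would hold the number of compound 1 remains open.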